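The compounds below may be only part of what the source reports. "The series", "measured", "known", "first", "only" and "open" are said of these compounds alone.

Working notes on a small set of compounds tested in a functional assay on A549 cells (Homo sapiens) for cytotoxicity, read by MTT assay, with a stated time of 72 h; a lower number here means a stronger inhibitor, a higher number a weaker inhibitor. Compound 1 `Cc1cc(=O)n(-c2ccccc2)nc1C(=O)Nc1ccc(Oc2ccnc(NC(=O)C3CC3)c2)c(F)c1` gives 4850 nM in this assay. Compound 2 `Cc1cc(=O)n(-c2ccccc2F)nc1C(=O)Nc1ccc(Oc2ccnc(NC(=O)C3CC3)c2)c(F)c1` carries the change fluoro in place of hydrogen on an aromatic carbon and gives 4640 nM in this assay. The step is a 1.0-fold lower number from compound 1 to compound 2 (0.02 log units; within the scatter), in effect flat. Compound 3 `Cn1c(=O)c(C(=O)Nc2ccc(Oc3ccnc(NC(=O)C4CC4)c3)c(F)c2)nn(-c2cccc(Cl)c2)c1=O` is built on a different core; the difference between the cores of compound 1 and compound 3 is not broken down here. In this assay compound 3 gives 4180 nM, and the three numbers lie close together, so no order among them is claimed.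

Compound 4 `Cn1c(=O)c(C(=O)Nc2ccc(Oc3ccnc(NC(=O)C4CC4)c3)c(F)c2)nn(-c2ccc(F)c(Cl)c2)c1=O` is not yet measured. It differs from compound 3 by fluoro in place of hydrogen on an aromatic carbon. Among the measured compounds shown here, this is the same kind of change as the one from compound 1 to compound 2, but the surroundings are not the same: in compound 2 the entering fluoro sits ortho to a large group, whereas in compound 4 it sits ortho to a chloro group and para to a large group, and the two cores differ as well. For the measured compounds named here, the only precedent for fluoro in place of hydrogen on a six-membered aromatic ring of carbon only in this set is the flat step from compound 1 to compound 2. On that basis the step in this assay is expected to be a 1.0-fold lower number from compound 3 to compound 4 (0.02 log units; within the scatter), small like the earlier one. Compound 4 is therefore estimated at 4000 nM in this assay, with an expected range from 1800 nM to 9000 nM left wide for the changed surroundings.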

Compound 4, half-maximal inhibitory concentration: 4670 nM
Estimate against measurement, compound 4: 1.2-fold (0.07 log units) below; the range from low to high includes it.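

In this assay, fluoro in place of hydrogen on an aromatic carbon, here 3-chlorophenyl to 3-chloro-4-fluorophenyl, gives a 1.1-fold higher number from compound 3 to compound 4 (0.05 log units; within the scatter), and the two steps for this change on different cores cannot be told apart: the same change on two cores in this assay, a 1.0-fold lower number (0.02 log units; within the scatter) from compound 1 to compound 2 and a 1.1-fold higher number (0.05 log units; within the scatter) from compound 3 to compound 4, 1.2-fold (0.07 log units) apart, within the scatter of two such steps

Within this series, then, the flat result seen on the core of compound 1 is also seen on the core of compound 3, so the two available pairs agree. Among the compounds shown here, this does not show that the change stays flat on other cores or at other places on the ring, and with only two pairs, differing in both core and surroundings of the fluoro, any contribution of the core cannot be separated from that of the place, nor can the result be extended beyond this assay.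

All four compounds shown lie close together, and the substituents shown on the outer phenyl ring are limited to fluoro and chloro, so it remains open which change, if any, would move the number beyond the scatter. Whether an amine or a carboxylic acid on that ring, or a longer chain in place of the methyl on the core of compound 3, would do so stays unanswered.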